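The source may hold more compounds than are shown below. What is called first, only, known or untested is meant among the compounds shown, and "the series" means these compounds.

Compound 1 `CC(O)(CSc1cccc(C(F)(F)F)c1)C(=O)Nc1ccc(S(F)(F)(F)(F)F)cc1`: 23400 nM. Compound 2 `CC(O)(CSc1cc(C(F)(F)F)cc(C(F)(F)F)c1)C(=O)Nc1ccc(S(F)(F)(F)(F)F)cc1`: 15800 nM. Compound 3 `CC(O)(COc1ccc(C#N)cc1)C(=O)Nc1ccc(S(F)(F)(F)(F)F)cc1`: 26100 nM.

In a functional assay on CWR22R cells (Homo sapiens) for antiproliferative activity, read by propidium iodide staining, with a stated time of 96 h (a lower number here means a stronger inhibitor, a higher number a weaker inhibitor), compound 1 gives 23400 nM and compound 2 gives 15800 nM. The change between them is trifluoromethyl in place of hydrogen on an aromatic carbon, and it made a 1.5-fold lower number from compound 1 to compound 2 (0.17 log units; within the scatter). Compound 3 gives 26100 nM in this assay; how its core differs from the core of compound 1 is not broken down here. Compound 4 `CC(O)(COc1ccc(C#N)cc1C(F)(F)F)C(=O)Nc1ccc(S(F)(F)(F)(F)F)cc1` is not yet measured. It differs from compound 3 by trifluoromethyl in place of hydrogen on an aromatic carbon, the same kind of change as that from compound 1 to compound 2, though here the entering group sits ortho to a large group and meta to a cyano group, whereas before it sat meta to a large group and meta to a trifluoromethyl group. The step from compound 3 to compound 4 is expected to be a 1.5-fold lower number from compound 3 to compound 4 (0.19 log units; within the scatter) because the same kind of change gave a 1.5-fold lower number from compound 1 to compound 2 (0.17 log units; within the scatter). Compound 4 is therefore estimated at 17000 nM, between 8000 nM and 40000 nM.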

Compound 4, half-maximal inhibitory concentration: 13800 nM
For compound 4 the middle estimate is 1.2-fold (0.09 log units) above the measured one; the range from low to high includes it.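

In this assay, trifluoromethyl in place of hydrogen on an aromatic carbon gave a 1.9-fold lower number from compound 3 to compound 4 (0.28 log units; within the scatter). Set beside the earlier step, the two results on different cores do not differ: the same change on two cores in this assay, a 1.5-fold lower number (0.17 log units; within the scatter) from compound 1 to compound 2 and a 1.9-fold lower number (0.28 log units; within the scatter) from compound 3 to compound 4, 1.3-fold (0.11 log units) apart, within the scatter of two such steps. This shows that the two cores agree, but each step alone lies within the scatter, so it does not show that the change truly lowers the number on either core, and two cores cannot establish a rule for the whole series.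

The compounds shown leave open whether another group at this place, such as chlorine or an amine, would give matching steps on both cores. They also leave open what a carboxylic acid in place of the cyano group would give.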